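A few compounds are considered here, and "the series" means these few. Any claim that something is new, unique, unknown or untested is made for them only; others in the source may bear on it.

In a functional assay on HEL cells (Homo sapiens) for inhibition, read by CellTiter-Glo, with a stated time of 48 h (on this read-out higher numbers stand for weaker inhibition of growth and lower numbers for stronger inhibition of growth), compound 1 `O=C(CCCCC(=O)N1C/C=C/COCc2cccc(c2)-c2ccnc(n2)Nc2cccc(c2)C1)NO` gives 2940 nM, compound 2 `O=C(CCCCN1C/C=C/CCOc2cccc(c2)-c2ccnc(n2)Nc2cccc(c2)C1)NO` gives 510 nM and compound 3 `O=C(CCCCCCN1C/C=C/COCc2cccc(c2)-c2ccnc(n2)Nc2cccc(c2)C1)NO` gives 700 nM. Compound 3 is thus within the scatter of compound 2, and its number is lower than that of compound 1. Compound 4 `O=C(CCCCCCC(=O)N1C/C=C/COCc2cccc(c2)-c2ccnc(n2)Nc2cccc(c2)C1)NO` carries (6-(hydroxycarbamoyl)hexyl)carbonyl in place of 6-(hydroxycarbamoyl)hexyl on an amine nitrogen in a ring, ((6-(hydroxycarbamoyl)hexyl)carbonyl in place of 6-(hydroxycarbamoyl)hexyl on an amine nitrogen in a ring). For the measured compounds named here, the one measured step that bears on this is a 4.2-fold lower number from compound 1 to compound 3 (0.62 log units; beyond the scatter), in which the carbonyl goes but the chain changes too. Going by the values given here, no measured step changes the carbonyl alone, so a smaller, opposite move is expected in this assay. The expected step is a 2.0-fold higher number from compound 3 to compound 4 (0.30 log units; within the scatter). For compound 4 the estimated value is 1400 nM, with an expected range of 500 nM to 4000 nM.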

Compound 4, concentration for 50% growth inhibition: 5030 nM
The estimate for compound 4 lay 3.6-fold (0.56 log units) below the measured number, and the stated range ends below it.
By their numbers in this assay, from the lowest: compounds 2 and 3 (each within the scatter of the next); then compounds 1 and 4 (each within the scatter of the next).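

In this assay the carbonyl on the ring nitrogen now has a step of its own: with the 6-(hydroxycarbamoyl)hexyl chain kept, adding it gives a 7.2-fold higher number from compound 3 to compound 4 (0.86 log units; beyond the scatter). With the carbonyl kept, the longer chain gives a 1.7-fold higher number from compound 1 to compound 4 (0.23 log units; within the scatter), so in this pair chain length does not separate the two compounds. No measurement at hand explains the loss that comes with the carbonyl. What the compounds shown leave open is whether a sulfonyl or a urea on the ring nitrogen would behave like the carbonyl, and whether a still longer chain would change these numbers.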